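Swapping benzyl for pyridazin-3-yl on the amide nitrogen

The source may hold more compounds than are shown below. What is called first, only, known or untested is meant among the compounds shown, and "the series" means these compounds.

Compound 1, `CC(C)C(C(N)=O)c1ccc(Cl)cc1`, in a functional assay on CHO cells for agonist activity at Free fatty acid receptor 2 (Homo sapiens), read by cAMP accumulation (on this read-out higher numbers stand for larger maximal responses and lower numbers for smaller maximal responses), gives < 30%, which is a limit of the assay and not a number.
Compound 2, `CC(C)[C@H](C(=O)NCc1ccccc1)c1ccc(Cl)cc1`, gives < 30%, again a limit of the assay.
Compound 3, `CC(C)C(C(=O)Nc1cnccn1)c1ccc(Cl)cc1`, gives 115%.

Compound 2 therefore stands at the floor of this assay, together with compound 1: the limit of < 30% in this assay, at which 2 of the 3 values shown sit. Only compound 3, carrying a pyrazin-2-yl group on the amide nitrogen, reaches a measured maximal response.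

The compound not yet measured is compound 4, `CC(C)[C@H](C(=O)Nc1cccnn1)c1ccc(Cl)cc1`. It differs from compound 2 in one place: pyridazin-3-yl in place of benzyl on an amide-type nitrogen.

Going by the values given here, the one measured step that bears on this change is a number at least 85 percentage points higher from compound 1 to compound 3 (beyond the scatter), where a six-membered aromatic ring with two nitrogen atoms entered the same position. That step started from a hydrogen, whereas compound 4 starts from a benzyl group, and compound 2 shows that benzyl on the amide nitrogen leaves the response at the limit. Since pyridazin-3-yl is, like pyrazin-2-yl, a six-membered aromatic ring with 2 hetero atoms, a large rise in this assay is expected for compound 4, a number at least 60 percentage points higher from compound 2 to compound 4 (beyond the scatter). Compound 4 is thus estimated at 90%, within a range of 40% to 130%.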

Compound 4, largest response reached (reported as efficacy), in percent of the reference or control that the assay uses: 101%
Beside the measured number, compound 4's estimate is 11 percentage points below it; the measured number falls inside the stated range.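

In this assay, the new result is a number at least 71 percentage points higher from compound 2 to compound 4 (beyond the scatter), so the rise at the amide-type nitrogen is not confined to a change that starts from the hydrogen of compound 1. Benzyl also brings a six-membered aromatic ring to this place, so such a ring alone does not go with a measured response; among the compounds shown, only compound 3 and compound 4, each with a six-membered aromatic ring with 2 hetero atoms, give one, and none goes against this pattern. The value of compound 2 is a limit of the assay and not a number, so the step gives a lower bound on the change and not its full size: the limit of < 30% in this assay, at which 2 of the 4 values shown sit.

The change from benzyl to pyridazin-3-yl alters two things at once, the atoms of the ring and the carbon that benzyl carries outside its ring, and the compounds shown cannot separate them. A phenyl group on the same nitrogen would address the first question, while pyridin-2-yl would show whether a ring with a single nitrogen behaves like pyridazin-3-yl.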